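Benzyl on the ring amine of compound 1

This account rests on a few compounds, and the source may have more. Where it says the series, first, only, none or still open, it means among the compounds named here.

Compound 1, with the structure `Nc1nc(-c2ccc(Cl)cc2)c(CC(=O)O)s1`, is the weakest point of the small set described here. In an in vitro assay on HEK385-7 cells for displacement of a labelled ligand from prostaglandin D2 receptor 2 (Homo sapiens) (on this read-out lower numbers stand for stronger inhibition and higher numbers for weaker inhibition), compound 1 gives > 100000 nM, and that figure is a limit of the assay rather than a measured number. Its position is summed up by the limit of > 100000 nM in this assay, at which 1 of the 3 values shown sits. Two other compounds of the same core carry a diarylmethyl group in place of the amino group. Compound 2, `O=C(O)Cc1sc(C(c2ccc(F)cc2)c2ccc(F)cc2)nc1-c1cn[nH]c1`, gives 16 nM in this assay. Compound 3, `O=C(O)Cc1sc(C(c2ccccc2)c2ccc(F)c(F)c2)nc1-c1ccc(F)cc1`, gives 10 nM in this assay; the two values lie within the scatter of each other, so neither is called the stronger.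

Compound 4, `O=C(O)Cc1sc(NCc2ccccc2)nc1-c1ccc(Cl)cc1`, has not yet been measured. It differs from compound 1 in one place: benzyl in place of hydrogen on a nitrogen on an aromatic ring. Within the data shown here, no measured pair separates this single change from the rest, so the size of the effect has to be judged from the gap between compound 1 and the two diarylmethyl compounds, which carry a different and larger substituent at that position.

Compound 4 is therefore expected to show a large gain in this assay by the step of an at least 33-fold lower number from compound 1 to compound 4 (1.52 log units; beyond the scatter), though it is not expected to reach the two diarylmethyl compounds. The estimate for compound 4 in this assay is 3000 nM, within 300 nM to 30000 nM.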

Compound 4, half-maximal inhibitory concentration: 440 nM
The estimate for compound 4 lay 6.8-fold (0.83 log units) above the measured number; low and high end bracket the measured number.
By their numbers in this assay, from the lowest: compounds 3 and 2 (each within the scatter of the next); then compound 4. At a limit, above all of these: compound 1.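

In this assay, among these compounds, benzyl in place of hydrogen on a nitrogen on an aromatic ring gives an at least 220-fold lower number from compound 1 to compound 4 (2.35 log units; beyond the scatter); this is the first pair that isolates one change at this position with the rest of the core held fixed, which compound 2 and compound 3 could not do, as each differs from compound 1 in more than one place. A single benzyl on that nitrogen is thus enough to give a measured value on the core of compound 1, with compound 4 at 440 nM. The step gives only the smallest size the change can have, because compound 1 stands at a limit and not at a measured number: the limit of > 100000 nM in this assay, at which 1 of the 4 values shown sits.

The compounds shown leave open how much of the step rests on the six-membered aromatic ring and how much on the added carbon alone, which a methyl or a cyclohexylmethyl on the same nitrogen would separate. They also leave open whether the nitrogen itself matters, as compound 4 differs from compound 2 and compound 3 in more than one place, and a methylene in place of that nitrogen would be needed to tell.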